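From 2,4-dihydroxyphenyl to 4-aminophenyl on a shared core

The source may hold more compounds than are shown below. What is called first, only, known or untested is meant among the compounds shown, and "the series" means these compounds.

In a functional assay on HT-29 cells (Homo sapiens) for inhibition, read by MTT assay, with a stated time of 48 h (on this read-out higher numbers stand for weaker inhibition and lower numbers for stronger inhibition), compound 1 (`COc1cc(-c2cc(-c3ccc(Br)cc3)nc(-c3ccccc3)n2)cc(OC)c1OC`) gives 3170 nM, and compound 3 (`COc1cc(-c2cc(-c3ccc(O)cc3O)nc(-c3ccccc3)n2)cc(OC)c1OC`) gives 4960 nM. These two values stand level, since a 1.6-fold higher number from compound 1 to compound 3 (0.19 log units; within the scatter) does not leave the scatter. Compound 2 (`COc1cc(-c2cc(-c3cccc([N+](=O)[O-])c3)nc(-c3ccccc3)n2)cc(OC)c1OC`) gives > 25000 nM, which is a limit of this assay. Compound 3 therefore sits with compound 1, and an at least 5.0-fold lower number from compound 2 to compound 3 (0.70 log units; beyond the scatter) separates it from compound 2.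

The next structure, compound 4 (`COc1cc(-c2cc(-c3ccc(N)cc3)nc(-c3ccccc3)n2)cc(OC)c1OC`), carries 4-aminophenyl in place of 2,4-dihydroxyphenyl on an aromatic carbon.

All three measured steps are swaps at this same carbon. One stays within the scatter, as noted, whereas an at least 7.8-fold higher number from compound 1 to compound 2 (0.89 log units; beyond the scatter) is clearly larger. Only the 3-nitrophenyl of compound 2 goes against the otherwise flat picture. Since compound 4 has no nitro group and the swap of compound 1 for compound 3 gave a 1.6-fold higher number from compound 1 to compound 3 (0.19 log units; within the scatter), no step beyond the scatter is expected, and the expected step is a 1.2-fold lower number from compound 3 to compound 4 (0.09 log units; within the scatter). Compound 4 is estimated at 4000 nM, with an expected range of 1300 nM to 13000 nM.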

Compound 4, half-maximal inhibitory concentration: > 25000 nM
Compound 4 was reported as a limit; the forecaster's own chance of this, stated with the estimate: 10%; middle value at least 6.2-fold (0.79 log units) away from the limit.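

In this assay, the loss at this carbon no longer belongs to the 3-nitrophenyl of compound 2 alone: 4-aminophenyl in place of 2,4-dihydroxyphenyl gives an at least 5.0-fold higher number from compound 3 to compound 4 (0.70 log units; beyond the scatter), and amino in place of bromo gives an at least 7.8-fold higher number from compound 1 to compound 4 (0.89 log units; beyond the scatter). The second change shows that this position tells 4-aminophenyl from 4-bromophenyl, so the flat picture of compound 1 and compound 3 does not extend to every group placed here. The step between compound 2 and compound 4 cannot be read, because both stand at the same limit: the limit of > 25000 nM in this assay, at which 2 of the 4 values shown sit.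

Going by these compounds, how far compound 2 and compound 4 lie past that limit stays open. So does whether a 4-hydroxyphenyl, 4-methoxyphenyl or 4-dimethylaminophenyl group at this carbon would sit with compound 1 or with compound 4.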